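This account rests on a few compounds, and the source may have more. Where it says the series, first, only, none or still open, it means among the compounds named here.

Of the compounds shown here, three of a shared core have been measured in an in vitro assay on 293-EBNA cells for binding affinity to corticotropin-releasing factor receptor 1 (Homo sapiens); on this read-out lower numbers stand for stronger inhibition and higher numbers for weaker inhibition. Compound 1 `CCCCN(CC)c1nc(C)nc2c1nnn2-c1c(C)cc(C)nc1C` gives 65 nM in this assay, compound 2 `CCN(CC)c1nc(C)nc2c1nnn2-c1ccc(C(C)C)cc1Br` gives 25.3 nM, and compound 3 `CCCCN(CC)c1nc(C)nc2c1nnn2-c1ccc(S(C)(=O)=O)cc1Br` gives 100 nM. Compound 2 stands lowest of the three numbers: compound 1 is its nearest neighbour, with a higher number that lies beyond the usual scatter, and compound 3 is furthest, again beyond the scatter. On these numbers compound 2 is the most potent of the set.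

Compound 4 `CCCCC(CCCC)Nc1nc(C)nc2c1nnn2-c1ccc(C(C)C)cc1Br` has not yet been measured. It differs from compound 2 in one place: a group of 10 heavy atoms (9 carbon, 1 nitrogen; no ring) in place of a group of 5 heavy atoms (4 carbon, 1 nitrogen; no ring), on an aromatic carbon. The group that leaves is the diethylamino group; the group that enters is a longer, branched chain of nine carbon atoms and one nitrogen, bringing one hydrogen-bond donor where compound 2 has none. For the measured compounds named here, no measured pair shows a change of this kind, so the size of the step cannot be read from the numbers in hand.

Compound 4 is expected to stay close to compound 2, with a step of a 1.3-fold lower number from compound 2 to compound 4 (0.10 log units; within the scatter) that is estimated to fall within or only slightly beyond the usual scatter, in the direction of a lower number. The estimate for compound 4 in this assay is 20 nM, within a range from 6 nM to 70 nM.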

Compound 4, inhibition constant: 4.5 nM
Compound 4: middle estimate off by 4.4-fold (0.65 log units), on the high side, outside the stated range (below it).
By their numbers in this assay, from the lowest: compound 4; then compound 2; then compounds 1 and 3 (each within the scatter of the next).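

For the compounds shown here, the position on the aromatic carbon next to the ring nitrogen, which no earlier pair could speak to, turns out to respond to its substituent in this assay: replacing the diethylamino group with the larger, unringed group of 10 heavy atoms gives a 5.6-fold lower number from compound 2 to compound 4 (0.75 log units; beyond the scatter), a step beyond the scatter. The position therefore accepts a much larger group with a gain rather than a loss, at least with the aryl group that compound 2 and compound 4 share. Going by these compounds alone, nothing measured here explains the gain, and the single step cannot separate the larger size of the entering group from the hydrogen-bond donor it brings.

An isopropylamino group, which would keep a hydrogen-bond donor on a much smaller group, and a dibutylamino group, which would carry a large group with no such donor, would be needed to pull those two changes apart. The compounds shown also leave open whether the entering group would have a similar effect with the aryl groups of compound 1 or compound 3.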